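This account rests on a few compounds, and the source may have more. Where it says the series, first, only, none or still open, it means among the compounds named here.

Measured in a functional assay on DU-145 cells (Homo sapiens) for inhibition; a higher number here means a weaker inhibitor, a lower number a stronger inhibitor:
- compound 1 `CCOc1ccc(Br)cc1-c1cc(Nc2ccc(B(O)O)cc2)nc(N)n1`: 500 nM
- compound 2 `CCOc1ccc(Br)cc1-c1cc(Nc2ccc(C#N)cc2)nc(N)n1`: 400 nM
- compound 3 `CCOc1ccc(Br)cc1-c1cc(Nc2cccc(C#N)c2)nc(N)n1`: > 1000 nM

Compound 3 reads > 1000 nM, and this is a limit of the assay, not a number. Going by the values given here, compound 2 gives 400 nM, and the only other true number lies close to it: a 1.3-fold lower number from compound 1 to compound 2 (0.10 log units; within the scatter).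

Compound 4 `CCOc1ccc(Br)cc1-c1cc(Nc2ccc(C(=O)NO)cc2)nc(N)n1` keeps the core of compound 2 and changes one group: hydroxycarbamoyl in place of cyano on an aromatic carbon. Hydroxycarbamoyl takes the place of cyano, on the same aromatic carbon, para to a large group.

Among the compounds with values here, two measured steps bear on this change. Within the data shown here, the nearest precedent is an exchange of one group for another at this same place, and it stayed small: a 1.3-fold lower number from compound 1 to compound 2 (0.10 log units; within the scatter). Moving the cyano group mattered more: an at least 2.5-fold higher number from compound 2 to compound 3 (0.39 log units; beyond the scatter). Compound 4 leaves the place of the group unchanged, so no step beyond the scatter is expected in this assay, though this rests on very few compounds.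

The expected step is no change at the digits printed from compound 2 to compound 4 (within the scatter). For compound 4 the estimated value is 400 nM, with an expected range of 150 nM to 1000 nM.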

Compound 4, half-maximal inhibitory concentration: > 1000 nM
Compound 4: only a limit was reported; the forecaster's own chance of this, stated with the estimate: 15%; at least 2.5-fold (0.39 log units) between middle value and limit.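

The earlier exchange at this aromatic carbon, para to a large group, stayed small, but this position does not accept every group: hydroxycarbamoyl in place of cyano gives an at least 2.5-fold higher number from compound 2 to compound 4 (0.39 log units; beyond the scatter). The comparison with the boron-bearing group is less firm, as the floor of this step lies within the scatter: an at least 2.0-fold higher number from compound 1 to compound 4 (0.30 log units; that floor lies within the scatter). Compound 4 gives only a limit, not a number, so the full size of both steps cannot be read: the limit of > 1000 nM in this assay, at which 2 of the 4 values shown sit.

The compounds shown do not tell whether the loss follows the larger group or the hydrogen-bond donors that hydroxycarbamoyl brings, and compound 3 and compound 4 cannot be ranked against each other. A plain carboxamide or a carboxylic acid on the same carbon would help to separate these features.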